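Ether-acid series: furan to thiophene swap at the benzylic carbon

A few compounds are considered here, and "the series" means these few. Any claim that something is new, unique, unknown or untested is made for them only; others in the source may bear on it.

Measured so far in an assay on A10 cells for antagonist activity at Endothelin-1 receptor (Rattus norvegicus); on this read-out higher numbers stand for weaker inhibition and lower numbers for stronger inhibition:
compound 1 `N#Cc1ccc(OCc2ccsc2)cc1OC(C(=O)O)c1ccc(Cl)cc1` gives 504 nM
compound 2 `N#Cc1ccc(OCc2ccsc2)cc1OC(C(=O)O)c1ccco1` gives 2400 nM

Compound 2 stands at the highest of the two numbers; its nearest neighbour is compound 1, and the step of a 4.8-fold higher number from compound 1 to compound 2 (0.68 log units; beyond the scatter) lies beyond the scatter, so compound 2 is the weaker of the pair on this read-out.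

Compound 3 `N#Cc1ccc(OCc2ccsc2)cc1OC(C(=O)O)c1ccsc1` is not yet measured. Its difference from compound 2 is thiophen-3-yl in place of furan-2-yl on a saturated chain carbon bound to a carbonyl carbon and an oxygen on an aromatic ring — one five-membered aromatic ring with 1 hetero atom replaced by another of the same size and count, with the hetero atom changed from oxygen to sulfur and the attachment moved from the 2-position of furan to the 3-position of thiophene.

Going by the values given here, only one measured step exists, a 4.8-fold higher number from compound 1 to compound 2 (0.68 log units; beyond the scatter), and it swaps 4-chlorophenyl for furan-2-yl, not one five-membered ring for another; it bears on the present change only loosely. Given that compound 1 sits at 504 nM and compound 2 at 2400 nM, compound 3 is expected to land between them, with the step of a 2.0-fold lower number from compound 2 to compound 3 (0.30 log units; within the scatter) estimated as modest and toward a lower number. The estimate for compound 3 in this assay is 1200 nM, with a range from 400 nM to 3500 nM.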

Compound 3, half-maximal inhibitory concentration: 630 nM
Compound 3: middle estimate off by 1.9-fold (0.28 log units), on the high side, within the range that was stated.
By their numbers in this assay, from the lowest: compounds 1 and 3 (each within the scatter of the next); then compound 2.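

Working notes, ring on the saturated chain carbon: in this assay the change shows up as a 3.8-fold lower number from compound 2 to compound 3 (0.58 log units; beyond the scatter) and lies beyond the scatter, so at this position two five-membered aromatic rings with 1 hetero atom and the same heavy atom count do not read alike. The second new step, a 1.3-fold higher number from compound 1 to compound 3 (0.10 log units; within the scatter), lies within the scatter, so thiophen-3-yl and 4-chlorophenyl cannot be told apart on this read-out, and a five-membered ring here does not by itself go with the higher number; of the three compounds, only compound 2, with furan-2-yl, stands apart. No supporting data are available to account for the difference between furan-2-yl and thiophen-3-yl at this position.

Because furan-2-yl and thiophen-3-yl differ in both hetero atom and attachment point, the compounds shown cannot assign the step to either change, and thiophen-2-yl or furan-3-yl at this carbon would separate the two. Also open, from the compounds shown here alone, is what the chlorine contributes to the value of compound 1, a question that plain phenyl at the same carbon would address.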